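The source may report more compounds than this note shows. Statements on the series, on what has been measured and on what is new or still open speak of the compounds shown alone.

Compound 1 `Nc1scc(CN2CCN(c3cccnc3)CC2)c1C(=O)c1ccc(Cl)cc1` and compound 2 `Nc1scc(CN2CCN(c3c(F)cccc3F)CC2)c1C(=O)c1cccc(C(F)(F)F)c1` share a common core and have both been examined in a functional assay on CHO cells with adenosine receptor A1 (Homo sapiens) as the target, read by cAMP accumulation and immunoassay, with a stated time of 6 min, tested at 10 uM; on this read-out lower numbers stand for a stronger effect and higher numbers for a weaker effect at the one concentration tested. Compound 1 gives -23% in this assay, while compound 2 gives 4%; compound 1 thus stands at the lower of the two numbers, and the gap between them lies beyond the usual scatter. For the measured compounds named here, no pair of measured compounds differing in a single place is available, so no measured single step can be quoted. Compound 3 `Nc1scc(CN2CCN(c3cc(Cl)ccc3Cl)CC2)c1C(=O)c1ccc(Cl)cc1` is yet to be measured in this assay; it differs from compound 1 by 2,5-dichlorophenyl in place of pyridin-3-yl on an amine nitrogen in a ring. With only the two measured values to rest on, a modest shift toward a weaker effect is expected, giving an estimated step of a number 13 percentage points higher from compound 1 to compound 3 (beyond the scatter), which may well stay within the scatter. Compound 3 is therefore expected to give about -10% in this assay, within a range from -35% to 15%.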

Compound 3, a percentage reported as activity, at one concentration (the size of the read-out at that concentration, not a potency): -62%
Compound 3: middle estimate off by 52 percentage points, on the high side; measured number outside the range, below it.
By their numbers in this assay, from the lowest: compound 3; then compound 1; then compound 2.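

For the compounds shown here, the exchange of pyridin-3-yl for 2,5-dichlorophenyl on an amine nitrogen in a ring gives, in this assay, a number 39 percentage points lower from compound 1 to compound 3 (beyond the scatter), a large step toward the stronger effect and the first measured single change in this set. It shows that this position is not indifferent to the aromatic ring it carries, since the read-out moves strongly while the rest of compound 1 stays the same. Nothing given here accounts for the size of this step.

Going by these compounds alone, the single step changes two things at once, as the ring nitrogen leaves and two chlorines enter, so their separate shares remain open. From the compounds shown here alone, an unsubstituted phenyl or a phenyl bearing one chlorine at this position would tell them apart, and whether the step carries over to other cores also remains open.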